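Adding amino to compound 2: what to expect

The source may report more compounds than this note shows. Statements on the series, on what has been measured and on what is new or still open speak of the compounds shown alone.

Measured so far in an ADME assay on Caco-2 cells (Homo sapiens) for permeability, in the apical to basolateral direction; on this read-out higher numbers stand for higher permeability and lower numbers for lower permeability
Compound 1 `C[C@H]1C[C@@H](c2ccncc2NC(=O)c2nc(-c3c(F)cccc3F)ncc2N)C[C@@H](O)[C@@]1(O)CF` gives 28 10^-6 cm/s
Compound 2 `C[C@H]1C[C@@H](c2ccncc2NC(=O)c2ccnc(-c3c(F)cccc3F)n2)C[C@@H](O)[C@]1(C)O` gives 13.4 10^-6 cm/s

Of these two numbers compound 2 holds the lower one, and the gap up to compound 1 lies beyond the usual scatter. Compound 3 `C[C@H]1C[C@@H](c2ccncc2NC(=O)c2nc(-c3c(F)cccc3F)ncc2N)C[C@@H](O)[C@]1(C)O` is compound 2 with a single change, amino in place of hydrogen on an aromatic carbon. For the measured compounds named here, no measured pair shows this change on its own, so any expectation stays loose. Compound 1, which also carries the amino group, reads 28 10^-6 cm/s in this assay but differs from compound 3 elsewhere as well. The estimated step is a 1.3-fold higher number from compound 2 to compound 3 (0.13 log units; within the scatter) in this assay, a modest rise that is expected to stay within the scatter. For compound 3 the expected value is 18 10^-6 cm/s (estimated range 8 10^-6 cm/s to 36 10^-6 cm/s).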

Compound 3, apparent permeability: 10.1 10^-6 cm/s
Estimate against measurement, compound 3: 1.8-fold (0.25 log units) above, within the range that was stated.
By their numbers in this assay, from the lowest: compounds 3 and 2 (each within the scatter of the next); then compound 1.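

In this assay, amino in place of hydrogen on an aromatic carbon can now be read on its own, and it gives a 1.3-fold lower number from compound 2 to compound 3 (0.12 log units; within the scatter), so at this place, para to a 2,6-difluorophenyl group, the change leaves the read-out within the scatter. The step beyond the scatter lies at a different place: hydrogen in place of fluoro on a saturated chain carbon bound to a saturated ring carbon gives a 2.8-fold lower number from compound 1 to compound 3 (0.44 log units; beyond the scatter). No measurement here offers an explanation for either step.

Open, on these data alone, is whether a methylamino or a methoxy group at this same place would read like amino. Also open, as far as these compounds go, is whether the amino change would give a similar step in a compound that keeps the fluoro on the chain.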